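The source may report more compounds than this note shows. Statements on the series, on what has been measured and on what is new or still open speak of the compounds shown alone.

Measured so far in an ADME assay on HepG2 2.2.15 cells (Homo sapiens) for cytotoxicity; a higher number here means that more compound is tolerated, a lower number that less compound is tolerated:
compound 1 `CCC(=O)OCCc1c(-c2ccccc2Cl)c2cc(Cl)ccc2[nH]c1=O` gives 95000 nM
compound 2 `CC(C)C(=O)OCCc1c(-c2ccccc2Cl)c2cc(Cl)ccc2[nH]c1=O` gives 62000 nM
compound 3 `O=C(OCCc1c(-c2ccccc2Cl)c2cc(Cl)ccc2[nH]c1=O)C1CCCCC1` gives 38000 nM

Compound 2 sits between the other two numbers, yet the step of a 1.5-fold lower number from compound 1 to compound 2 (0.19 log units; within the scatter) and the step of a 1.6-fold lower number from compound 2 to compound 3 (0.21 log units; within the scatter) both fall within the scatter, so no real separation from either neighbour is shown. For the measured compounds named here, the only step beyond the scatter is the one from compound 1 to compound 3 a 2.5-fold lower number from compound 1 to compound 3 (0.40 log units; beyond the scatter), a modest lowering on exchange of a small acyl group for a larger ring-bearing one.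

Compound 4 `CC12CCC(C(=O)OCCc3c(-c4ccccc4Cl)c4cc(Cl)ccc4[nH]c3=O)(OC1=O)C2(C)C` continues in that direction: a group of 11 heavy atoms (9 carbon, 2 oxygen; one five-membered non-aromatic ring of carbon only, one five-membered non-aromatic ring with 1 hetero atom) in place of a group of 3 heavy atoms (3 carbon; no ring), on a carbonyl carbon. Going by the values given here, the entering group is far larger than anything measured here, and the one clear step, from compound 1 to compound 3 a 2.5-fold lower number from compound 1 to compound 3 (0.40 log units; beyond the scatter), points toward a lower tolerated concentration as the acyl group grows. Among the compounds with values here, a modest lowering in this assay is therefore expected, a 1.8-fold lower number from compound 2 to compound 4 (0.25 log units; within the scatter), though with only two acyl steps to lean on the direction is not firmly anchored. Compound 4 is estimated at 35000 nM, with a range from 15000 nM to 80000 nM.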

Compound 4, half-maximal cytotoxic concentration: > 1800000 nM
Compound 4: only a limit was reported; the forecaster's own chance of this, stated with the estimate: 10%; at least 51-fold (1.71 log units) between middle value and limit.
By their numbers in this assay, from the lowest: compounds 3, 2 and 1 (each within the scatter of the next, the first and the last beyond it). At a limit, above all of these: compound 4.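

In this assay compound 4 is reported only as a limit, not as a number: the limit of > 1800000 nM in this assay, at which 1 of the 4 values shown sits.

All three steps to it are large and point the same way (an at least 29-fold higher number from compound 2 to compound 4 (1.46 log units; beyond the scatter); an at least 47-fold higher number from compound 3 to compound 4 (1.67 log units; beyond the scatter); an at least 18-fold higher number from compound 1 to compound 4 (1.27 log units; beyond the scatter)). The position on the carbonyl carbon can therefore carry a far larger group with two five-membered rings, and tolerance in this assay is not lost. Compound 4 goes against the lowering seen with the cyclohexyl group (a 2.5-fold lower number from compound 1 to compound 3 (0.40 log units; beyond the scatter)), so the heavy-atom count alone does not order these esters.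

The compounds shown do not separate which part of the entering group goes with the change, and the limit leaves the size of each step open. As far as these compounds go, whether a longer chain or a plain cyclopentyl group on the carbonyl carbon would fall with compound 3 or with compound 4 also remains open.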